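The source may hold more compounds than are shown below. What is called first, only, known or untested is meant among the compounds shown, and "the series" means these compounds.

Measured in an ADME assay on MT4 cells (Homo sapiens) for cytotoxicity, read by MTT assay; a lower number here means that less compound is tolerated, a higher number that more compound is tolerated:
- Compound 1 `Cc1c(Cc2c(F)cccc2F)nc(Nc2ccc(C#N)cc2)[nH]c1=O`: > 2830 nM
- Compound 2 `CC(c1cc(=O)[nH]c(Nc2ccc(C#N)cc2)n1)c1c(F)cccc1F`: > 2830 nM
- Compound 3 `CC(c1cc(Cl)nc(Nc2ccc(C#N)cc2)n1)c1c(F)cccc1F`: > 2690 nM

None of these results is an exact number. Compound 3 stands at the limit of > 2690 nM in this assay, at which 1 of the 3 values shown sits. Compound 1 and compound 2 share (the limit of > 2830 nM in this assay, at which 2 of the 3 values shown sit).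

Compound 4 `Cc1c(Cl)nc(Nc2ccc(C#N)cc2)nc1C(C)c1c(F)cccc1F` differs from compound 3 by one small change: methyl in place of hydrogen on an aromatic carbon. This is methyl in place of hydrogen on an aromatic carbon. Among the measured compounds shown here, no measured pair of compounds isolates this change, and limits cannot give the size of a step. The expectation is therefore no shift beyond the usual scatter in this assay, and the result may again be only a limit. The estimated at least 1.0-fold lower number from compound 3 to compound 4 (0.01 log units; that floor lies within the scatter) is correspondingly small. Compound 4 is expected at 2600 nM, within an estimated range of 1300 nM to 5200 nM.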

Compound 4, half-maximal cytotoxic concentration: > 13000 nM
Compound 4: a limit, no number; the forecaster's own chance of this, stated with the estimate: 80%; middle value at least 5.0-fold (0.69 log units) from the limit.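

Among the compounds shown here, compound 3 and compound 4 are both given only as limits in this assay, so no step between them can be read. The compounds shown leave open whether methyl in place of hydrogen on an aromatic carbon shifts this read-out at all.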